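The source may report more compounds than this note shows. Statements on the series, on what has been measured and on what is new or still open speak of the compounds shown alone.

Measured compounds:
compound 1 `COC1=C(C)C(=O)/C(=C(O)/C=C/c2ccc(OC)cc2)C(=O)C1(C)C` gives 2.8 ug/mL in a functional assay on 1A9 cells (Homo sapiens) for cytotoxicity; a higher number here means that more compound is needed for the effect, a lower number that less compound is needed;
for compound 2 `C=Cc1ccccc1/C=C/C(O)=C1/C(=O)C(C)=C(OC)C(C)(C)C1=O` the entry in this assay is "not determined" (no result reported), so no result is reported for it.

Going by the values given here, compound 1 therefore holds the only number known so far in this assay, and it stands alone, since for compound 2 nothing can be compared.

Compound 3 `COC1=C(C)C(=O)/C(=C(O)/C=C/c2nccs2)C(=O)C1(C)C` differs from compound 1 at one place: 1,3-thiazol-2-yl in place of 4-methoxyphenyl on a double-bonded chain carbon bound to a double-bonded chain carbon. Among the compounds with values here, no step between measured compounds has been recorded, so the size of this change has to be judged without a precedent. A change of the aromatic group on the double-bonded chain carbon is expected to move the read-out somewhat, most likely toward a higher number, though perhaps not beyond the usual scatter. The expected step of a 1.8-fold higher number from compound 1 to compound 3 (0.25 log units; within the scatter) is moderate and upward.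

Compound 3 is expected to give 5 ug/mL in this assay, with a range from 1.8 ug/mL to 14 ug/mL.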

Compound 3, concentration for half-maximal effect: 3.5 ug/mL
Beside the measured number, compound 3's estimate is 1.4-fold (0.15 log units) above it, within the range that was stated.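

In this assay, going by these compounds alone, the first step at this position is a 1.3-fold higher number from compound 1 to compound 3 (0.10 log units; within the scatter), for 1,3-thiazol-2-yl in place of 4-methoxyphenyl on a double-bonded chain carbon bound to a double-bonded chain carbon. The result shows that a five-membered aromatic ring with 2 hetero atoms can stand here in place of a six-membered aromatic ring of carbon only without the read-out moving beyond the usual scatter, so this exchange leaves the cytotoxicity of the shared core effectively unchanged. No available measurement bears on why the two groups give such similar results.

The compounds shown leave open whether an aromatic ring is needed at this position at all. From the compounds shown here alone, it also remains unknown how the read-out would respond to a simple alkyl chain, an amine or a carboxylic acid in place of the ring.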